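This account rests on a few compounds, and the source may have more. Where it says the series, first, only, none or still open, it means among the compounds named here.

Measured so far in an assay on CHO cells for inhibition of sodium- and chloride-dependent glycine transporter 1 (Homo sapiens), read by scintillation counting; on this read-out lower numbers stand for an effect already at smaller amounts and higher numbers for an effect only at larger amounts of compound:
compound 1 `C[C@H](Oc1ccc(S(C)(=O)=O)cc1C(=O)N1Cc2cc(C(F)(F)F)cnc2C1)C(F)(F)F`, 50 nM;
compound 2 `CS(=O)(=O)c1ccc(OCCC(F)(F)F)c(C(=O)N2Cc3cc(C(F)(F)F)cnc3C2)c1`, 111 nM;
compound 3 `CS(=O)(=O)c1ccc(OCCC(F)(F)F)c(C(=O)N2Cc3ccc(C4CCOCC4)cc3C2)c1`, 137 nM.

Compound 2 stands second highest of these three numbers. Its nearest neighbour is compound 3, whose value lies within the scatter of it, while compound 1 is set apart by the step of a 2.2-fold higher number from compound 1 to compound 2 (0.35 log units; beyond the scatter).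

Compound 4 `CS(=O)(=O)c1ccc(-c2ccc(F)c(F)c2)c(C(=O)N2Cc3cc(C(F)(F)F)cnc3C2)c1` differs from compound 2 in one place: 3,4-difluorophenyl in place of 3,3,3-trifluoropropoxy on an aromatic carbon. For the measured compounds named here, the only measured step available, a 2.2-fold higher number from compound 1 to compound 2 (0.35 log units; beyond the scatter), bears on this position, but it only reshapes the fluorinated chain on the oxygen and was modest in size. Going by the values given here, no measured step replaces the oxygen-linked chain by an aromatic ring, so the direction of the change from compound 2 to compound 4 rests on no precedent here, and a wide range is warranted.

The step of a 1.2-fold higher number from compound 2 to compound 4 (0.07 log units; within the scatter) is thus expected to stay within the scatter. Compound 4 is expected to give about 130 nM in this assay, with a range from 35 nM to 500 nM.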

Compound 4, half-maximal effective concentration: 30 nM
Beside the measured number, compound 4's estimate is 4.3-fold (0.64 log units) above it; the measured number lies below the stated range.
By their numbers in this assay, from the lowest: compounds 4 and 1 (each within the scatter of the next); then compounds 2 and 3 (each within the scatter of the next).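

Until now, this position para to a methylsulfonyl group had carried only oxygen-linked fluorinated chains, but the oxygen link and the open chain prove not to be needed. In this assay, a six-membered aromatic ring of carbon only, the 3,4-difluorophenyl group, gives a 3.7-fold lower number from compound 2 to compound 4 (0.57 log units; beyond the scatter), a larger change than the reshaping of the chain had produced. Against the branched 1-(trifluoromethyl)ethoxy group, the same ring gives a 1.7-fold lower number from compound 1 to compound 4 (0.22 log units; within the scatter), so these two groups cannot be told apart, and nothing available accounts for the difference from the 3,3,3-trifluoropropoxy group.

On these data alone, it remains open whether a plain phenyl or a pyridine ring would serve as well at this position, and thus whether the two ring fluorines matter. Also open, as far as these compounds go, is whether the 3,4-difluorophenyl group would have the same effect on the core of compound 3.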